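The source may hold more compounds than are shown below. What is called first, only, known or untested is meant among the compounds shown, and "the series" means these compounds.

Three compounds have so far been tested in a functional assay on MGC-803 cells (Homo sapiens) for inhibition, read by sulforhodamine B assay, with a stated time of 72 h, tested at 10 uM; a lower number here means less inhibition, a higher number more inhibition at the concentration tested (going by the name of the read-out):

compound 1, `Cc1cc(Nc2ccc(C(=O)/C=C/c3cccc(Br)n3)cc2)n2nc(SCc3ccc(F)cc3)nc2n1`: 93.3%
compound 2, `Cc1cc(Nc2ccc(C(=O)/C=C/c3cccc(Br)n3)cc2)n2nc(SCc3ccc([N+](=O)[O-])cc3)nc2n1`: 91.6%
compound 3, `Cc1cc(Nc2ccc(C(=O)/C=C/c3cccc(Br)n3)cc2)n2nc(SCCCc3ccccc3)nc2n1`: 76.7%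

Compound 3 stands lowest of the three, and both gaps lie beyond the scatter: a number 16.6 percentage points lower from compound 1 to compound 3 (beyond the scatter), and a number 14.9 percentage points lower from compound 2 to compound 3 (beyond the scatter). The two higher compounds differ from each other only on the aromatic ring, and that step, a number 1.7 percentage points lower from compound 1 to compound 2 (within the scatter), stays within the scatter.

Compound 4, `Cc1cc(Nc2ccc(C(=O)/C=C/c3cccc(Br)n3)cc2)n2nc(SCc3nc4ccccc4[nH]3)nc2n1`, differs from compound 3 in one place: 1H-benzimidazol-2-yl in place of phenethyl on a saturated chain carbon bound to a sulfur.

The two steps that bear on this both ran the other way: each replaced an aromatic ring on the saturated chain carbon bound to a sulfur with phenethyl, and each lowered inhibition by a modest amount. Which substituent sat on that ring made no difference beyond the scatter. Compound 4 returns an aromatic ring to that carbon, although a different one carrying two nitrogens and a hydrogen-bond donor, so a modest rise is expected: a number 11.3 percentage points higher from compound 3 to compound 4 (beyond the scatter). On that basis compound 4 is estimated to give 88%, with the expected range running from 74% to 96%.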

Compound 4, a percentage reported as inhibition, at one concentration (the size of the read-out at that concentration, not a potency): 94.4%
The estimate for compound 4 lay 6.4 percentage points below the measured number, and the stated range covers the measured number.
By their numbers in this assay, from the lowest: compound 3; then compounds 2, 1 and 4 (each within the scatter of the next).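

In this assay, the saturated chain carbon bound to a sulfur accepts more than one kind of aromatic group: 1H-benzimidazol-2-yl in place of phenethyl gives the modest step of a number 17.7 percentage points higher from compound 3 to compound 4 (beyond the scatter) and brings the number back up to the level of the two substituted phenyl compounds. The steps of a number 2.8 percentage points higher from compound 2 to compound 4 (within the scatter) and a number 1.1 percentage points higher from compound 1 to compound 4 (within the scatter) show that swapping 4-nitrophenyl or 4-fluorophenyl for this two-ring group, with its added nitrogen, hydrogen-bond donor and hydrogen-bond acceptor, changes nothing that this read-out can separate, so neither that donor nor that acceptor is needed to keep the number high. No measurement at hand explains any of these steps.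

Still open, on these data alone, is whether the hydrogen on the ring nitrogen matters, which a 1-methyl-1H-benzimidazol-2-yl group would test, and whether a non-aromatic group on that carbon, such as a piperidine ring or a carboxylic acid, would keep the number high. With a single tested concentration, compounds 1, 2 and 4 also remain unranked, and only full concentration-response curves could show whether they truly differ in potency.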